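This account rests on a few compounds, and the source may have more. Where it says the series, first, only, none or still open, it means among the compounds named here.

Of the compounds shown here, two from this set have been tested in an assay on HEK293 cells for positive allosteric modulation of metabotropic glutamate receptor 5 (Homo sapiens), read by FLIPR; on this read-out higher numbers stand for an effect only at larger amounts of compound and lower numbers for an effect already at smaller amounts. Compound 1 `CC1CCCCC1C(=O)N1CC(c2nc(-c3cccc(F)c3)no2)C1` carries a saturated ring on the carbonyl, and in this assay compound 1 gives 540 nM. Compound 2 `O=C(c1ccc(F)cc1)N1CC(c2nc(-c3cccc(Cl)c3)no2)C1` carries a 4-fluorophenyl on the same carbonyl and a 3-chlorophenyl on its other end. In this assay compound 2 returns only a limit of the assay, > 10000 nM, and not a number. From the compounds shown here alone, compound 2 therefore sits at the limit of > 10000 nM in this assay, at which 1 of the 2 values shown sits, and where it stands within that region is unknown.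

Compound 3 `O=C([C@H]1CC2CCC1C2)N1CC(c2nc(-c3cccc(Cl)c3)no2)C1` has not yet been measured. It differs from compound 2 in one place: a group of 7 heavy atoms (7 carbon; 2 five-membered non-aromatic rings of carbon only) in place of a group of 7 heavy atoms (6 carbon, 1 fluorine; one six-membered aromatic ring of carbon only), on a carbonyl carbon. The saturated carbonyl substituent of compound 3 resembles that of compound 1 more than it resembles the aromatic one of compound 2, and compound 1 gives 540 nM in this assay. The step from compound 2 to compound 3 in this assay is therefore expected to be an at least 12-fold lower number from compound 2 to compound 3 (1.09 log units; beyond the scatter), in the direction of an effect at smaller amounts. For compound 3 the estimated value is 800 nM, with a range from 200 nM to 4000 nM.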

Compound 3, half-maximal effective concentration: 74 nM
For compound 3 the middle estimate is 11-fold (1.03 log units) above the measured one; the whole stated range lies above it.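

Compound 2 and compound 1 differ in more than one place, so they could not show what the group on the carbonyl carbon contributes on its own. Among the compounds shown here, compound 3 keeps the 3-chlorophenyl end of compound 2 and changes only that group, and in this assay this single exchange of the 4-fluorophenyl for the saturated two-ring carbon group gives an at least 130-fold lower number from compound 2 to compound 3 (2.13 log units; beyond the scatter). Both groups hold the same count of heavy atoms and neither has a hydrogen-bond donor or acceptor, so this pair shows that the read-out depends strongly on the group at this place even when those counts stay the same, and the true size of the step remains unknown because compound 2 returns only a limit of the assay: the limit of > 10000 nM in this assay, at which 1 of the 3 values shown sits.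

One pair cannot separate the loss of the aromatic ring from the particular two-ring framework of compound 3 or its defined stereocentre. From the compounds shown here alone, how a plain cyclohexyl, an open chain such as pentyl or a saturated ring carrying an amine would read at this carbonyl carbon in this assay also stays open.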